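The compounds below may be only part of what the source reports. "The series", "measured", "known", "first", "only" and "open" are said of these compounds alone.

In a functional assay on DU-145 cells (Homo sapiens) for inhibition, read by trypan blue exclusion, with a stated time of 96 h (a lower number here means a stronger inhibitor of growth, a higher number a weaker inhibitor of growth), compound 1 `Cc1ccc(S/C(=C/c2ccc(Br)cc2)C(=O)c2ccc(Cl)cc2)cc1` gives 25000 nM, compound 2 `O=C(/C(=C\c1ccc(Br)cc1)SCc1ccc(Cl)cc1)c1ccc(Cl)cc1` gives 1000 nM, and compound 3 `Cc1ccc(CS/C(=C/c2ccc(Br)cc2)C(=O)c2ccc(Cl)cc2)cc1` gives 10000 nM. Compound 3 thus stands second highest of the three numbers: its nearest neighbour is compound 1, and its furthest is compound 2, as the steps of a 2.5-fold lower number from compound 1 to compound 3 (0.40 log units; beyond the scatter) and a 10-fold higher number from compound 2 to compound 3 (1.00 log units; beyond the scatter) show. Compound 4 `Cc1ccc(CS/C(=C/c2ccccc2Br)C(=O)c2ccc(Cl)cc2)cc1` differs from compound 3 in one place: 2-bromophenyl in place of 4-bromophenyl on a double-bonded chain carbon bound to a double-bonded chain carbon.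

Within the data shown here, none of the measured steps touch this part of the molecule. The steps of a 25-fold lower number from compound 1 to compound 2 (1.40 log units; beyond the scatter), a 2.5-fold lower number from compound 1 to compound 3 (0.40 log units; beyond the scatter) and a 10-fold higher number from compound 2 to compound 3 (1.00 log units; beyond the scatter) all change the group on the sulfur or the substituent on its aromatic ring, while the 4-bromophenyl group stays the same in compounds 1, 2 and 3. There is therefore no measured guide to what exchanging it for 2-bromophenyl does, and the expectation is that the step of no change at the digits printed from compound 3 to compound 4 (within the scatter) stays within the scatter, with a wide range to allow for the unknown. Compound 4 is estimated at 10000 nM, between 3000 nM and 35000 nM.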

Compound 4, concentration for 50% growth inhibition: 10000 nM
Compound 4: the middle estimate sits on the measured number at the digits printed; the measured number falls inside the stated range.
By their numbers in this assay, from the lowest: compound 2; then compounds 3 and 4 (each within the scatter of the next); then compound 1.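

In this assay, among these compounds, the exchange of 4-bromophenyl for 2-bromophenyl on a double-bonded chain carbon bound to a double-bonded chain carbon gives no change at the digits printed from compound 3 to compound 4 (within the scatter), the first measured step at this position. With the 4-methylbenzyl group on the sulfur held fixed, this pair shows that the bromine can occupy either of these two ring positions with no difference beyond the scatter, though this rests on a single pair. Nothing available explains this result.

As far as these compounds go, whether the same holds with the 4-chlorobenzyl group of compound 2 on the sulfur remains open. Also open, from the compounds shown here alone, is how this position would respond if an amine or a carboxylic acid stood on the phenyl ring in place of the bromine.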